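The compounds below may be only part of what the source reports. "The series", "measured", "known", "first", "only" and "open" are said of these compounds alone.

Compound 1 `O=[N+]([O-])c1ccc(-c2nc3cc(C(F)(F)F)ccc3[nH]2)cc1` carries a nitro group on the aromatic ring that hangs from the shared core. In an ADME assay on MT4 cells (Homo sapiens) for cytotoxicity, read by MTT assay, with a stated time of 96 h (a higher number here means that more compound is tolerated, a lower number that less compound is tolerated), compound 1 gives 6000 nM, which is the lowest of the two numbers recorded in this assay. The nearest neighbour is compound 2 `O=[N+]([O-])c1ccc(-c2nc3cc(C(F)(F)F)ccc3[nH]2)c([N+](=O)[O-])c1`, which in this assay gives 9000 nM; the step of a 1.5-fold higher number from compound 1 to compound 2 (0.18 log units; within the scatter) comes from a nitro in place of hydrogen on an aromatic carbon and stays within the scatter.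

Compound 3 `CCN(CC)CC(=O)Nc1ccc(-c2nc3cc(C(F)(F)F)ccc3[nH]2)cc1` has not yet been measured in this assay. It differs from compound 1 by (((diethylamino)methyl)carbonyl)amino in place of nitro on an aromatic carbon. Going by the values given here, no measured step bears directly on this change: the only step recorded, a 1.5-fold higher number from compound 1 to compound 2 (0.18 log units; within the scatter), adds a second nitro while keeping the first, whereas in compound 3 the nitro itself leaves and the (((diethylamino)methyl)carbonyl)amino group enters. With both recorded numbers within the scatter of each other, there is no ground to expect a step beyond the scatter in either direction. Compound 3 is therefore expected to give about 8000 nM in this assay, with a range from 3000 nM to 25000 nM, meaning an expected step of a 1.3-fold higher number from compound 1 to compound 3 (0.12 log units; within the scatter).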

Compound 3, half-maximal cytotoxic concentration: 8000 nM
Estimate against measurement, compound 3: no gap at the digits printed, within the range that was stated.
By their numbers in this assay, from the lowest: compounds 1, 3 and 2 (each within the scatter of the next).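

In this assay, the aromatic carbon that carries the nitro in compound 1, para to a large group, takes a quite different substituent with only a small shift: the exchange of nitro for (((diethylamino)methyl)carbonyl)amino gives a 1.3-fold higher number from compound 1 to compound 3 (0.12 log units; within the scatter). Going by these compounds alone, the earlier step kept the first nitro in place, so this is the first sign that the number stays within the scatter when that nitro is gone altogether, even though 9 heavy atoms and 1 hydrogen-bond donor enter where 3 heavy atoms and no donor leave. Nothing measured here explains why this exchange leaves the number within the scatter.

The three compounds do not tell whether a simple amine, a plain acetamide or a carboxylic acid at this carbon would also stay within the scatter, nor whether a longer chain between the carbonyl and the diethylamino group would do so. They also leave open whether the trifluoromethyl on the shared core has any bearing on these numbers, since it is common to all three.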